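Carbamate Oxygen Replaced by a Dichlorinated Aryl Ring

The source may report more compounds than this note shows. Statements on the series, on what has been measured and on what is new or still open speak of the compounds shown alone.

Within the data shown here, compound 2 `CC(C)OC(=O)Nc1c(C(O)(C(F)(F)F)C(F)(F)F)ccc2ccccc12` gives 1160 nM in an assay on LtK cells with ATP-sensitive inward rectifier potassium channel 11 (Homo sapiens) as the target (on this read-out higher numbers stand for an effect only at larger amounts of compound and lower numbers for an effect already at smaller amounts), the lowest of the two numbers measured so far. Among the measured compounds shown here, compound 1 `O=C(NCCCCCCCl)Nc1c(C(O)(C(F)(F)F)C(F)(F)F)ccc2ccccc12` gives 4840 nM in this assay, and the step of a 4.2-fold lower number from compound 1 to compound 2 (0.62 log units; beyond the scatter) is the only measured step available. Compound 3 `O=C(Nc1c(C(O)(C(F)(F)F)C(F)(F)F)ccc2ccccc12)c1ccc(Cl)c(Cl)c1` has not yet been measured; it differs from compound 2 by 3,4-dichlorophenyl in place of isopropoxy on a carbonyl carbon. The measured step from compound 1 to compound 2 altered the same carbonyl carbon, so it bears on this change, yet it exchanged two groups of which neither resembles a 3,4-dichlorophenyl ring, so it gives no direct guide to the size or direction of the new step. The step of a 1.3-fold higher number from compound 2 to compound 3 (0.11 log units; within the scatter) is therefore expected to stay within the scatter. Compound 3 is estimated at 1500 nM in this assay, with a range from 400 nM to 6000 nM.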

Compound 3, half-maximal effective concentration: 194 nM
Beside the measured number, compound 3's estimate is 7.7-fold (0.89 log units) above it; measured number outside the range, below it.
By their numbers in this assay, from the lowest: compound 3; then compound 2; then compound 1.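

At the carbonyl carbon, in this assay, the isopropoxy group can give way to a 3,4-dichlorophenyl ring with a 6.0-fold lower number from compound 2 to compound 3 (0.78 log units; beyond the scatter), which shows that this position accepts an aromatic ring attached directly to the carbonyl and that the oxygen of the isopropoxy group is not required for the lowest number seen so far. Among these compounds, measured against the (6-chlorohexyl)amino group, the same ring gives a 25-fold lower number from compound 1 to compound 3 (1.40 log units; beyond the scatter), the largest step so far, and so this one position alone spans a wide range of values on the shared core. Nothing available here offers a measured property that would account for these steps.

The compounds shown do not separate the contribution of the ring from that of its two chlorines, a question that a plain phenyl or a 4-chlorophenyl group would address. Also open, from the compounds shown here alone, is how a pyridine ring, or a methylene link between the carbonyl and the ring, would fare at this position.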